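Replacing the dimethoxyphenyl arm of the urea

The compounds below may be only part of what the source reports. "The series", "measured", "known", "first", "only" and "open" are said of these compounds alone.

Compound 1, `COc1cc(NC(=O)Nc2cc(Nc3ccc(C)c(C)c3)ncn2)cc(OC)c1`, gives 45.3% in a functional assay on NCI-H226 cells (Homo sapiens) for inhibition, read by MTT assay, with a stated time of 48 h, tested at 10 uM; on this read-out higher numbers stand for more inhibition at the one concentration tested (going by the name of the read-out) and lower numbers for less inhibition.
Compound 2, `COc1cc(NC(=O)Nc2cc(Nc3cccc(C(C)(C)C)c3)ncn2)cc(OC)c1`, gives 40%.
Compound 3, `COc1cc(NC(=O)Nc2cc(Nc3ccc(C)c(F)c3)ncn2)cc(OC)c1`, gives 39.7%.

Compound 2 stands second highest of the three, though nothing separates it from its neighbours: the step of a number 0.3 percentage points lower from compound 2 to compound 3 (within the scatter) and the step of a number 5.3 percentage points lower from compound 1 to compound 2 (within the scatter) both lie within the scatter, as does a number 5.6 percentage points lower from compound 1 to compound 3 (within the scatter). Compound 4, `CC(C)(C)c1cccc(Nc2cc(NC(=O)Nc3c(Cl)cccc3Cl)ncn2)c1`, is built from compound 2 by a change at a different place: 2,6-dichlorophenyl in place of 3,5-dimethoxyphenyl on an amide-type nitrogen. All three measured steps alter the aryl on the other nitrogen, not the group on the amide-type nitrogen, so none of them bears directly on this change. With no guidance either way, the expected step is none beyond the scatter, no change at the digits printed from compound 2 to compound 4 (within the scatter). Compound 4 is therefore estimated at 40%, within 20% to 60%.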

Compound 4, a percentage reported as inhibition, at one concentration (the size of the read-out at that concentration, not a potency): 36.5%
For compound 4 the middle estimate is 3.5 percentage points above the measured one; the range from low to high includes it.
By their numbers in this assay, from the lowest: compounds 4, 3, 2 and 1 (each within the scatter of the next).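

Compounds 1 to 3 differ only in the aryl on the other nitrogen, whereas compound 4 changes the group on the amide-type nitrogen. In this assay, the step of a number 3.5 percentage points lower from compound 2 to compound 4 (within the scatter) shows that, for this one pair, 2,6-dichlorophenyl and 3,5-dimethoxyphenyl cannot be told apart at this position. No measurement at hand accounts for this result.

From the compounds shown here alone, it remains open whether a piperidine or a plain butyl chain in place of 3,5-dimethoxyphenyl on the amide-type nitrogen would read differently. Going by these compounds, it is also open whether 2,6-dichlorophenyl gives a similar number with 3,4-dimethylphenyl on the other nitrogen.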